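The compounds below may be only part of what the source reports. "The series", "measured", "known", "first", "only" and "open" are said of these compounds alone.

Compound 1 `Cc1ccccc1-c1nnc(SCc2ccc(Cl)nc2)o1`: 8.51 ug/mL
Compound 2 `Cc1ccc(-c2nnc(SCc3ccc(Cl)nc3)o2)cc1`: 3.62 ug/mL
Compound 3 `COc1ccccc1-c1nnc(SCc2ccc(Cl)nc2)o1`: 8.2 ug/mL

In a functional assay on SGC-7901 cells (Homo sapiens) for antiproliferative activity, read by MTT assay, with a stated time of 48 h (a lower number here means a stronger inhibitor, a higher number a weaker inhibitor), compound 2 gives 3.62 ug/mL as the lowest of the three numbers, and moving the methyl accounts for a 2.4-fold lower number from compound 1 to compound 2 (0.37 log units; beyond the scatter) on this series. Compound 4 `COc1ccc(-c2nnc(SCc3ccc(Cl)nc3)o2)cc1` carries methoxy in place of methyl on an aromatic carbon, para to a large group (methoxy in place of methyl on an aromatic carbon). Among the compounds with values here, the same exchange of groups at another place gave a 1.0-fold lower number from compound 1 to compound 3 (0.02 log units; within the scatter) and is the only measured precedent. That step starts from a different compound, so its transfer remains uncertain. No step beyond the scatter is expected in this assay, and the estimate is a 1.1-fold higher number from compound 2 to compound 4 (0.04 log units; within the scatter) in either direction. Expected for compound 4 is 4 ug/mL (2 ug/mL to 8.5 ug/mL).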

Compound 4, half-maximal inhibitory concentration: 3.5 ug/mL
Compound 4: middle estimate off by 1.1-fold (0.06 log units), on the high side; low and high end bracket the measured number.
By their numbers in this assay, from the lowest: compounds 4 and 2 (each within the scatter of the next); then compounds 3 and 1 (each within the scatter of the next).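

In this assay, methoxy in place of methyl on an aromatic carbon, para to a large group, gives a 1.0-fold lower number from compound 2 to compound 4 (0.01 log units; within the scatter), so methyl and methoxy are not told apart at this position. The exchange can now be read at two places, and the two steps agree: the same change on two cores in this assay, a 1.0-fold lower number (0.02 log units; within the scatter) from compound 1 to compound 3 and a 1.0-fold lower number (0.01 log units; within the scatter) from compound 2 to compound 4, 1.0-fold (0.00 log units) apart, within the scatter of two such steps

Still open, on these data alone, is whether an amine, a carboxylic acid or a longer chain at this place would move the number beyond the scatter. Also open, as far as these compounds go, is whether the exchange would stay as flat with the chloro group on the shared core replaced by an amine.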